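The source may hold more compounds than are shown below. What is called first, only, known or untested is meant among the compounds shown, and "the series" means these compounds.

Compound 3 `O=C(Nc1c(C(O)(C(F)(F)F)C(F)(F)F)ccc2ccccc12)c1ccccc1` is the starting point here. In an assay on LtK cells with ATP-sensitive inward rectifier potassium channel 11 (Homo sapiens) as the target (on this read-out higher numbers stand for an effect only at larger amounts of compound and lower numbers for an effect already at smaller amounts), compound 3 gives 44 nM. Two other compounds share its core and differ only in the group on the carbonyl carbon: compound 1 `C/C=C/C(=O)Nc1c(C(O)(C(F)(F)F)C(F)(F)F)ccc2ccccc12` gives 72 nM in this assay, and compound 2 `CC(C)CCC(=O)Nc1c(C(O)(C(F)(F)F)C(F)(F)F)ccc2ccccc12` gives 49 nM. The three numbers sit close together, as the steps of a 1.6-fold lower number from compound 1 to compound 3 (0.21 log units; within the scatter), a 1.1-fold lower number from compound 2 to compound 3 (0.05 log units; within the scatter) and a 1.5-fold lower number from compound 1 to compound 2 (0.17 log units; within the scatter) show; none of them leaves the scatter, so compound 3 cannot be set apart from the other two on this read-out.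

Compound 4 `O=C(Nc1c(C(O)(C(F)(F)F)C(F)(F)F)ccc2ccccc12)c1ccccc1Cl` is obtained from compound 3 by chloro in place of hydrogen on an aromatic carbon. Among the compounds with values here, none of the measured steps bears directly on this change: each of them swaps the whole group on the carbonyl carbon rather than adding something to a phenyl ring that stays in place, and even those larger swaps stayed within the scatter. Within the data shown here, there is thus no measured step that points to a shift in either direction. Compound 4 is therefore expected to stay close to compound 3, with an expected step of a 1.1-fold lower number from compound 3 to compound 4 (0.04 log units; within the scatter) in this assay. The estimate for compound 4 is 40 nM, with a range from 15 nM to 120 nM.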

Compound 4, half-maximal effective concentration: 2040 nM
For compound 4 the middle estimate is 51-fold (1.71 log units) below the measured one; the measured number lies above the stated range.
By their numbers in this assay, from the lowest: compounds 3, 2 and 1 (each within the scatter of the next); then compound 4.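

In this assay, adding a single chloro to the phenyl ring of compound 3 gives a 46-fold higher number from compound 3 to compound 4 (1.67 log units; beyond the scatter) and so shows that this one ring position, ortho to a large group, matters greatly on this read-out, which the swaps of the whole group on the carbonyl carbon among compounds 1, 2 and 3 had not revealed. The 2-chlorophenyl group also separates compound 4 from the isopentyl and prop-1-en-1-yl amides, with a 42-fold higher number from compound 2 to compound 4 (1.62 log units; beyond the scatter) and with a 28-fold higher number from compound 1 to compound 4 (1.45 log units; beyond the scatter) as the two further steps, so among these four compounds only this group on the carbonyl carbon moves the number beyond the scatter. Nothing given here accounts for this loss or ties it to any property of the chloro group.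

The compounds shown leave open whether a fluoro, a methyl or a methoxy group at this same position would raise the number as far as chloro does, or whether any substituent there is enough. They also leave open whether chloro on another carbon of the phenyl ring would have a comparable effect, and whether an amine or a carboxylic acid would be tolerated at this position.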